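This account rests on a few compounds, and the source may have more. Where it says the series, first, only, none or still open, it means among the compounds named here.

For the measured compounds named here, compound 1, `Cc1ncnc2c1c(I)cn2[C@@H]1O[C@H](CO)[C@@H](O)[C@H]1O`, is the one member of this set for which a number rather than a limit is available in a functional assay on K562 cells (Homo sapiens), read by MTT assay, with a stated time of 72 h; a lower number here means a stronger inhibitor, a higher number a weaker inhibitor: compound 1 gives 17800 nM. Compound 2, `C#Cc1cn([C@@H]2O[C@H](CO)[C@@H](O)[C@H]2O)c2nc(N)nc(OC)c12`, reaches only a limit of the assay in this assay, > 20000 nM. Compound 3, `CNc1ncnc2c1c(I)cn2[C@@H]1O[C@H](CO)[C@@H](O)[C@H]1O`, likewise reaches only a limit in this assay, > 100000 nM. Going by the values given here, the step of an at least 5.6-fold higher number from compound 1 to compound 3 (0.74 log units; beyond the scatter) is therefore the single measured step, and it involves (the limit of > 100000 nM in this assay, at which 1 of the 3 values shown sits).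

Compound 4, `Cc1ncnc2c1c(-c1ccsc1)cn2[C@@H]1O[C@H](CO)[C@@H](O)[C@H]1O`, differs from compound 1 at a different site: thiophen-3-yl in place of iodo on an aromatic carbon. Among the compounds with values here, no measured step touches this position, since the one step known, from methyl to methylamino, concerns another aromatic carbon of the shared core. There is thus no measured guide to the direction or the size of the change, and a change of either sign cannot be excluded on the numbers shown.

In the absence of a relevant step, the estimate for compound 4 in this assay is placed near compound 1 but with a wide range, a step of a 3.0-fold lower number from compound 1 to compound 4 (0.47 log units; beyond the scatter) being the expectation. Compound 4 is expected to give about 6000 nM, between 600 nM and 40000 nM.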

Compound 4, half-maximal inhibitory concentration: 320 nM
Compound 4: middle estimate off by 19-fold (1.27 log units), on the high side; the whole stated range lies above it.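

In this assay the exchange of iodo for thiophen-3-yl, on the aromatic carbon two ring bonds from the ring nitrogen, gives a 56-fold lower number from compound 1 to compound 4 (1.75 log units; beyond the scatter) and so shows that this position, untouched by the earlier step, responds strongly to the group it carries. The one earlier step lay at another aromatic carbon of the shared core and raised the number, which makes this the first change among the compounds shown that lowers it. The measurements shown offer no explanation for the size of this step.

On these data alone, with a single replacement at this position, it remains open whether the gain belongs to thiophen-3-yl in particular or would also appear with a phenyl ring, a furan-3-yl ring, thiophen-2-yl or a non-aromatic group such as aminomethyl. It also remains open whether thiophen-3-yl would lower the number to a similar extent with methylamino in place of methyl on the core, as that combination of the two changes is not among the compounds shown here.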